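Swapping 1-methylpyrrolidin-3-yl for azetidin-3-yl on a shared core

The source may report more compounds than this note shows. Statements on the series, on what has been measured and on what is new or still open speak of the compounds shown alone.

In a functional assay on NCI-H2228 cells (Homo sapiens) for inhibition, read by CellTiter-Glo, with a stated time of 96 h (on this read-out higher numbers stand for weaker inhibition and lower numbers for stronger inhibition), compound 1 (`Cc1cc(Nc2ncc(Cl)c(Nc3cn(C)nc3S(=O)(=O)C(C)C)n2)c(OC(C)C)cc1C1CCN(C)C1`) gives 131 nM and shares the low end of the three numbers in hand with compound 2 (`Cc1cc(Nc2ncc(Cl)c(Nc3cn(C)nc3S(=O)(=O)C(C)C)n2)c(OC2CC2)cc1C(=O)C(C)C`) at 149 nM as the two lie within the scatter of each other. Compound 3 (`Cc1cc(Nc2ncc(Cl)c(Nc3cn(C)nc3S(=O)(=O)C(C)C)n2)c(C(F)(F)F)cc1C1CCN(C)CC1`) stands apart at 1080 nM and its number is higher than that of compound 1 by more than the scatter.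

The next compound, compound 4 (`Cc1cc(Nc2ncc(Cl)c(Nc3cn(C)nc3S(=O)(=O)C(C)C)n2)c(OC(C)C)cc1C1CNC1`), keeps the core of compound 1 and changes one group. The change is azetidin-3-yl in place of 1-methylpyrrolidin-3-yl on an aromatic carbon and it sits on an aromatic carbon ortho to a methyl group and meta to an isopropoxy group.

No two measured compounds differ in one place only, so the size of this step in this assay is not shown directly. Compound 2 carries a quite different group in that place, along with a second difference, and its 149 nM still stays within the scatter of compound 1. The ring swap is therefore expected to bring no step beyond the scatter. The estimated change is a 1.2-fold lower number from compound 1 to compound 4 (0.08 log units; within the scatter) with little weight on its direction. For compound 4 the expected value is 110 nM with an estimated range from 40 nM to 320 nM as the likely span.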

Compound 4, half-maximal inhibitory concentration: 288 nM
Estimate against measurement, compound 4: 2.6-fold (0.42 log units) below; low and high end bracket the measured number.
By their numbers in this assay, from the lowest: compounds 1, 2 and 4 (each within the scatter of the next, the first and the last beyond it); then compound 3.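

In this assay, among the compounds shown here, the first direct reading of a single change on the shared core shows that this place is sensitive to the group it carries: azetidin-3-yl in place of 1-methylpyrrolidin-3-yl gives a 2.2-fold higher number from compound 1 to compound 4 (0.34 log units; beyond the scatter) and so goes with weaker inhibition, though the step is modest. The swap alters more than one feature at once, as a five-membered non-aromatic ring gives way to a four-membered one and the entering group carries a hydrogen-bond donor that the leaving group lacks, so this single step cannot assign the higher number to any one of these differences. Nothing measured here offers an explanation for the step.

The compounds shown leave open whether ring size or the methyl group on the ring nitrogen goes with the step, a question that 1-methylazetidin-3-yl and pyrrolidin-3-yl in this place would separate. They also leave open how an open-chain amine such as dimethylaminomethyl would behave on the same aromatic carbon, and whether the step would hold with a cyclopropoxy group in place of the isopropoxy group.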